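The source may report more compounds than this note shows. Statements on the series, on what has been measured and on what is new or still open speak of the compounds shown alone.

In a physicochemical assay for solubility, at pH 1.1 (on this read-out higher numbers stand for higher solubility and lower numbers for lower solubility), compound 1 (`CCCN(Cc1ccc(OCCn2c(=O)ccn(C)c2=O)c(C)c1)C(CC(=O)O)c1ccc(Cl)cc1`) gives 3000000 nM and compound 2 (`COc1cc(CN(CC(C)C)C(CC(=O)O)c2ccc3c(c2)CCO3)ccc1OCCN1C(=O)CCC1=O`) gives 3000000 nM, so compound 2 stands level with compound 1. Compound 3 (`COc1cc(CN(CC(C)C)C(CC(=O)O)c2ccc(Cl)cc2Cl)ccc1OCCN1C(=O)CCC1=O`) brings in 2,4-dichlorophenyl on the saturated chain carbon bound to an amine nitrogen and a saturated chain carbon: a group of 8 heavy atoms (6 carbon, 2 chlorine; one six-membered aromatic ring of carbon only) in place of a group of 9 heavy atoms (8 carbon, 1 oxygen; one five-membered non-aromatic ring with 1 hetero atom, one six-membered aromatic ring of carbon only), on a saturated chain carbon bound to an amine nitrogen and a saturated chain carbon. Going by the values given here, no measured pair isolates a single change, so the data give no direct guide to this one. In this assay, no step beyond the scatter is expected, and the expected step is a 1.2-fold lower number from compound 2 to compound 3 (0.08 log units; within the scatter). Compound 3 is estimated at 2500000 nM, with an expected range of 1200000 nM to 3500000 nM.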

Compound 3, solubility: 3000000 nM
Estimate against measurement, compound 3: 1.2-fold (0.08 log units) below; the range from low to high includes it.
By their numbers in this assay, from the lowest: compounds 1, 2 and 3 (each within the scatter of the next).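

In this assay, the first pair differing in one place reads no change at the digits printed from compound 2 to compound 3 (within the scatter) when 2,4-dichlorophenyl replaces the earlier group on the saturated chain carbon bound to an amine nitrogen and a saturated chain carbon. This position therefore accepts a change from the group with one hydrogen-bond acceptor to one with none, and with two chlorine atoms, without separating the two compounds on this read-out. No measurement available here bears on why the two read level.
Still open, going by these compounds, is whether a phenyl group carrying an amine at this position would also read level.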